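A few compounds are considered here, and "the series" means these few. Any claim that something is new, unique, unknown or untested is made for them only; others in the source may bear on it.

Measured so far:
compound 1 `COc1ccc(COc2ccc3c(c2)[C@@H](O)CN(C)C3)cc1` gives > 50000 nM
compound 2 `CN1Cc2ccc(OCc3cccc(Br)c3)cc2[C@@H](O)C1` gives 60300 nM

Both numbers come from an ADME assay on Vero cells (Chlorocebus sabaeus) for cytotoxicity, read by sulforhodamine B assay, with a stated time of 72 h; on this read-out lower numbers stand for stronger inhibition and higher numbers for weaker inhibition. For compound 1 the result is a limit of the assay rather than a number, as the limit of > 50000 nM in this assay, at which 1 of the 2 values shown sits, shows. Compound 3 `COc1cccc(-c2ccc(COc3ccc4c(c3)[C@@H](O)CN(C)C4)cc2)c1` has not been measured there. It differs from compound 1 by 3-methoxyphenyl in place of methoxy on an aromatic carbon, that is, a 3-methoxyphenyl in place of methoxy on an aromatic carbon. Within the data shown here, no measured pair of this kind is available, so the size of the change is open. Compound 3 is expected near 35000 nM, within 10000 nM to 100000 nM. This would be a small downward step, an at least 1.4-fold lower number from compound 1 to compound 3 (0.15 log units; that floor lies within the scatter), expected to stay close to the usual scatter.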

Compound 3, half-maximal inhibitory concentration: 10800 nM
Beside the measured number, compound 3's estimate is 3.2-fold (0.51 log units) above it; the measured number falls inside the stated range.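

In this assay, this position proves sensitive to the group it carries. Replacing methoxy with 3-methoxyphenyl, which adds an aromatic ring, gives an at least 4.6-fold lower number from compound 1 to compound 3 (0.66 log units; beyond the scatter), so the cells are inhibited more strongly. Only the lowest possible size of this step is known, because the result for compound 1 is a limit of the assay: the limit of > 50000 nM in this assay, at which 1 of the 3 values shown sits.

From the compounds shown here alone, it remains open whether the added ring or the methoxy on it goes with this change. Also open, going by these compounds, is how a plain phenyl, or a phenyl bearing an amine or a carboxylic acid, would behave here.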